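The source may hold more compounds than are shown below. What is called first, only, known or untested is meant among the compounds shown, and "the series" means these compounds.

Working notes on the series. Compound 1 `COc1ccc(-c2ccnc(C(=O)Nc3ccc(Oc4ccnc5cc(OCCCN6CCCCC6)c(OC)cc45)c(F)c3)c2)cc1` is the reference point. For the measured compounds named here, in a functional assay on MKN-45 cells (Homo sapiens) for cytotoxicity, read by MTT assay, with a stated time of 72 h (on this read-out higher numbers stand for weaker inhibition and lower numbers for stronger inhibition), compound 1 gives 570 nM, the highest of the three numbers measured so far. Compound 2 `COc1ccc(-c2ccnc(C(=O)Nc3ccc(Oc4ccnc5cc(OCCCN6CCN(C)CC6)c(OC)cc45)c(F)c3)c2)cc1` gives 250 nM in this assay, and compound 3 `COc1ccc(-c2ccnc(C(=O)Nc3ccc(Oc4ccnc5cc(OCCCN6CCCC6)c(OC)cc45)c(F)c3)c2)cc1` gives 150 nM. The measured steps all concern the amine at the end of the chain: a 2.3-fold lower number from compound 1 to compound 2 (0.36 log units; beyond the scatter); a 3.8-fold lower number from compound 1 to compound 3 (0.58 log units; beyond the scatter); and a 1.7-fold lower number from compound 2 to compound 3 (0.22 log units; within the scatter).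

Compound 4 `COc1cc2c(Oc3ccc(NC(=O)c4cc(-c5ccc(C)cc5)ccn4)cc3F)ccnc2cc1OCCCN1CCCCC1` keeps the piperidin-1-yl end of compound 1 and changes the far end of the molecule instead: methyl in place of methoxy on an aromatic carbon. Going by the values given here, none of the measured steps touches this position, so nothing bears on it directly; the three measured steps only show how much this assay moves for changes at the chain amine, and nothing about the methoxy end. Among the compounds with values here, with no measured step at that position, the expectation for compound 4 is a number close to that of compound 1, with no step beyond the scatter in either direction. Compound 4 is therefore expected at about 600 nM in this assay, between 250 nM and 1500 nM. This amounts to an expected step of a 1.1-fold higher number from compound 1 to compound 4 (0.02 log units; within the scatter).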

Compound 4, half-maximal inhibitory concentration: 1670 nM
The estimate for compound 4 lay 2.8-fold (0.44 log units) below the measured number; the measured number lies above the stated range.
By their numbers in this assay, from the lowest: compounds 3 and 2 (each within the scatter of the next); then compound 1; then compound 4.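

The far end of the molecule is not silent in this assay: with the piperidin-1-yl end held constant, 4-methylphenyl in place of 4-methoxyphenyl gives a 2.9-fold higher number from compound 1 to compound 4 (0.47 log units; beyond the scatter), a move towards weaker inhibition. This shows that the methoxy group, on an aromatic carbon para to a large group, matters in this read-out, and that a change here can register beyond the scatter, as changes at the chain amine do in a 2.3-fold lower number from compound 1 to compound 2 (0.36 log units; beyond the scatter) and a 3.8-fold lower number from compound 1 to compound 3 (0.58 log units; beyond the scatter). No measurement shown here accounts for the step, so the loss of the oxygen, with the hydrogen-bond acceptor counted for methoxy, is only a description of the change and not an explanation of it.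

The compounds shown leave open how other groups on this carbon would read, such as hydroxy, chloro or ethoxy, and so whether an oxygen at this place is what counts. They also leave open whether the step carries over to the pyrrolidin-1-yl or 4-methylpiperazin-1-yl chain ends, as it is seen here only with piperidin-1-yl.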